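Octyloxy in place of pyrazolylethoxy on the shared core

The source may report more compounds than this note shows. Statements on the series, on what has been measured and on what is new or still open speak of the compounds shown alone.

Three measured members of the series carry different groups on a saturated ring carbon of a shared core. Compound 1 `Cc1nn(-c2ncnc3nc[nH]c23)c2c1C(c1ccc(F)cc1Cl)CC(=O)N2` gives 9 nM in a functional assay on HEK293 cells for agonist activity at G-protein coupled receptor 39 (Homo sapiens), read by scintillation proximity assay and inositol phosphate accumulation, with a stated time of 75 min, in the presence of a further agent that is not named here; a lower number here means that less compound is needed, a higher number that more compound is needed for the effect. Compound 2 `Cc1nn(-c2ncnc3nc[nH]c23)c2c1C(C(=O)NCc1ccccc1)CC(=O)N2` gives 5 nM in this assay, and compound 3 `Cc1nn(-c2ncnc3nc[nH]c23)c2c1C(OCCn1cccn1)CC(=O)N2` gives 16 nM in this assay. Compound 3 has the highest number of the three: the step of a 1.8-fold higher number from compound 1 to compound 3 (0.25 log units; within the scatter) stays within the scatter, while the step of a 3.2-fold higher number from compound 2 to compound 3 (0.51 log units; beyond the scatter) is modest but beyond it. The step of a 1.8-fold lower number from compound 1 to compound 2 (0.26 log units; within the scatter) is also within the scatter.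

Compound 4 `CCCCCCCCOC1CC(=O)Nc2c1c(C)nn2-c1ncnc2nc[nH]c12` is not yet measured. It differs from compound 3 as follows.

hexyl in place of 1H-pyrazol-1-yl on a saturated chain carbon, two bonds along the chain from an oxygen on a saturated carbon

The measured steps that bear on this all exchange the whole group on the same saturated ring carbon; none of them puts hexyl in place of 1H-pyrazol-1-yl at the end of a chain, so the comparison is indirect. Those steps are small: 2-chloro-4-fluorophenyl, benzylcarbamoyl and 2-(1H-pyrazol-1-yl)ethoxy all give numbers in a narrow band. The expectation is therefore no step beyond the scatter, with a slight lean towards a higher number, the expected step being a 1.4-fold higher number from compound 3 to compound 4 (0.14 log units; within the scatter). Compound 4 is estimated at 22 nM in this assay, with a range from 8 nM to 65 nM.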

Compound 4, half-maximal effective concentration: 8 nM
Beside the measured number, compound 4's estimate is 2.8-fold (0.44 log units) above it, and the stated range covers the measured number.
By their numbers in this assay, from the lowest: compounds 2, 4, 1 and 3 (each within the scatter of the next, the first and the last beyond it).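

In this assay the saturated ring carbon keeps its place in the series when the side chain carries no ring at all: the chain end changes from a five-membered aromatic ring to plain hexyl, with no hydrogen-bond acceptor left in the entering group, and the result is a 2.0-fold lower number from compound 3 to compound 4 (0.30 log units; within the scatter). Octyloxy also falls in with the two groups that have no ether chain, with a 1.6-fold higher number from compound 2 to compound 4 (0.20 log units; within the scatter) and a 1.1-fold lower number from compound 1 to compound 4 (0.05 log units; within the scatter), so among these compounds the terminal 1H-pyrazol-1-yl is not required for a number in this band, and an aromatic ring in the group at this position is not required either. Nothing on hand accounts for any of these steps.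

The compounds shown hold one unbranched ether chain without a ring, so they leave open how the number responds to a shorter chain such as butoxy, a longer one such as dodecyloxy, or octyl placed on the ring carbon without the ether oxygen. They also leave open whether the chain end accepts a charged group, such as an amine or a carboxylic acid.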